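This account rests on a few compounds, and the source may have more. Where it says the series, first, only, none or still open, it means among the compounds named here.

The compounds described here share one core and were each tested in a functional assay on WI-38 VA13 cells (Homo sapiens) for cytotoxicity; on this read-out higher numbers stand for an effect only at larger amounts of compound and lower numbers for an effect already at smaller amounts. Compound 1, `Cc1c(C(=O)c2ccccc2-c2ccccc2)oc2cc(-c3ccccc3)cc(O)c12`, gives 0.1 ug/mL in this assay. Compound 2, `Cc1ncsc1CCOC(=O)c1oc2cc(-c3ccccc3)cc(O)c2c1C`, gives 0.055 ug/mL in this assay. Compound 3, `Cc1c(C(=O)Cc2ccccc2)oc2cc(-c3ccccc3)cc(O)c12`, gives > 4 ug/mL in this assay, and that is a limit of the assay rather than a measured number. Compound 3 thus stands at the limit of > 4 ug/mL in this assay, at which 1 of the 3 values shown sits, the only one of the three without a definite value. Going by the values given here, the single step measured between two compounds in this assay is an at least 72-fold higher number from compound 2 to compound 3 (1.86 log units; beyond the scatter), where benzyl replaced 2-(4-methyl-1,3-thiazol-5-yl)ethoxy on a carbonyl carbon.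

Compound 4, `Cc1c(C(=O)CCc2ccccc2)oc2cc(-c3ccccc3)cc(O)c12`, differs from compound 3 by benzyl in place of phenyl on a saturated chain carbon bound to a carbonyl carbon. Among the compounds with values here, no measured step mirrors this lengthening of the chain by one carbon; the step from compound 2 to compound 3 changed a different group. The expectation for the step from compound 3 to compound 4 in this assay is therefore a step that the limit leaves unreadable from compound 3 to compound 4, no change beyond the scatter. Compound 4 is estimated at 5 ug/mL, between 1.5 ug/mL and 20 ug/mL, most likely again reported only as a limit.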

Compound 4, half-maximal effective concentration: > 4 ug/mL
Compound 4 ended at the assay's limit; the forecaster's own chance of this, stated with the estimate: 70%; the middle value does not contradict the limit.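

On the carbonyl carbon, phenethyl in place of 2-(4-methyl-1,3-thiazol-5-yl)ethoxy gives an at least 72-fold higher number from compound 2 to compound 4 (1.86 log units; beyond the scatter) in this assay. The large step seen with compound 3 is therefore not confined to benzyl: a second carbon-only chain ending in phenyl, longer by one carbon, also lies far from compound 2. The step between compound 3 and compound 4 cannot be read, because both compounds rest on the same limit of the assay rather than on measured numbers: the limit of > 4 ug/mL in this assay, at which 2 of the 4 values shown sit.

On these data alone, how far compound 3 and compound 4 lie beyond that limit stays open, and so does whether a still longer chain, or an amine at the end of the chain, would behave the same way. Also open, as far as these compounds go, is whether a plain 2-phenylethoxy group on the carbonyl carbon would stay close to compound 2, which would separate the role of the ester oxygen from that of the thiazole ring.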